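Dichloro analogues in a benzyl-chloride purine series

A few compounds are considered here, and "the series" means these few. Any claim that something is new, unique, unknown or untested is made for them only; others in the source may bear on it.

Compound 1 `ClCc1ccc(Cn2cnc3c(Cl)ncnc32)cc1` is the shared starting point; in a functional assay on EKVX cells (Homo sapiens) for cytotoxicity, read by sulforhodamine B assay, with a stated time of 48 h (on this read-out lower numbers stand for stronger inhibition of growth and higher numbers for weaker inhibition of growth), compound 1 gives 6920 nM. Compound 3 `ClCc1ccc(Cn2cnc3c(Cl)nc(Cl)nc32)cc1` carries chloro in place of hydrogen on an aromatic carbon and gives 31600 nM in this assay, a step of a 4.6-fold higher number from compound 1 to compound 3 (0.66 log units; beyond the scatter). Compound 2 `ClCc1cccc(Cn2cnc3ncnc(Cl)c32)c1` has the same atoms as compound 1 joined differently; the difference between the two cores is not broken down here. In this assay compound 2 gives 29500 nM, with the values of compound 2 and compound 3 within the scatter of each other. Compound 4 `ClCc1cccc(Cn2cnc3nc(Cl)nc(Cl)c32)c1` is not yet measured; it differs from compound 2 by chloro in place of hydrogen on an aromatic carbon, the same change as from compound 1 to compound 3. Going by the values given here, for compound 4 a step of about a 3.4-fold higher number from compound 2 to compound 4 (0.53 log units; beyond the scatter) is expected in this assay, resting on the single earlier instance a 4.6-fold higher number from compound 1 to compound 3 (0.66 log units; beyond the scatter). Compound 4 is therefore estimated at 100000 nM, with a range of 35000 nM to 300000 nM; compound 2 and compound 3 go against any claim beyond this.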

Compound 4, concentration for total growth inhibition: 2130 nM
Estimate against measurement, compound 4: 47-fold (1.67 log units) above, and the stated range ends above it.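

In this assay chloro in place of hydrogen on an aromatic carbon gives a 14-fold lower number from compound 2 to compound 4 (1.14 log units; beyond the scatter), so the step does not carry over between these two cores and its direction reverses: the same change on two cores in this assay, a 4.6-fold higher number (0.66 log units; beyond the scatter) from compound 1 to compound 3 and a 14-fold lower number (1.14 log units; beyond the scatter) from compound 2 to compound 4, 63-fold (1.80 log units) apart, beyond the scatter of two such steps

A step read on the core of compound 1 therefore cannot be transferred to the core of compound 2 in this series. This does not show why the two cores respond differently, and one pair per core gives no rule for any further core.

On these data alone, whether an amine or a methoxy group on that same carbon would also give opposite steps on the two cores stays open. Also open, as far as these compounds go, is whether a longer chain in place of the chloromethyl group would keep the low number of compound 4.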